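Series notes: cytotoxicity expectation for compound 4

The compounds below may be only part of what the source reports. "The series", "measured", "known", "first", "only" and "open" are said of these compounds alone.

The series shares one core carrying an aryl group at one end and a furan amide at the other. Compound 1 is `COc1ccccc1-c1csc(NC(=O)c2ccc([N+](=O)[O-])o2)n1`; compound 2 is `O=C(Nc1nc(-c2cccc(C(F)(F)F)c2)cs1)c1ccc([N+](=O)[O-])o1`; compound 3 is `COc1cccc(-c2csc(NC(=O)c3ccc(N)o3)n2)c1`; compound 4, not yet tested, is `CS(=O)(=O)Nc1cccc(-c2csc(NC(=O)c3ccc([N+](=O)[O-])o3)n2)c1`.

In an ADME assay on Vero cells (Chlorocebus sabaeus) for cytotoxicity, read by MTT assay, with a stated time of 72 h (a higher number here means a weaker inhibitor, a lower number a stronger inhibitor), compound 1 gives 42000 nM. In this assay compound 2 gives 23900 nM, the lowest of the two numbers reported, though compound 1 stands a short way above it and the two lie within the scatter of each other. In this assay compound 3 gives "not determined" (no result reported), so nothing can be said of it.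

From compound 2 to compound 4 the change is methanesulfonamido in place of trifluoromethyl on an aromatic carbon. Among the measured compounds shown here, no step between measured compounds is available for this change, and the two values so far, both well apart from any strongly cytotoxic range, give no direction. The expected step from compound 2 to compound 4 in this assay is a 1.7-fold higher number from compound 2 to compound 4 (0.22 log units; within the scatter), a small rise that stays within the scatter or only just beyond it. Compound 4 is therefore estimated at 40000 nM in this assay, with a range from 15000 nM to 120000 nM.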

Compound 4, half-maximal inhibitory concentration: < 2820 nM
Compound 4 was reported as a limit; the forecaster's own chance of this, stated with the estimate: 25%; at least 14-fold (1.15 log units) between middle value and limit.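

In this assay, methanesulfonamido in place of trifluoromethyl on an aromatic carbon, meta to a large group, gives an at least 8.4-fold lower number from compound 2 to compound 4 (0.92 log units; beyond the scatter). Among the compounds shown here, this is the only step read, and it shows that a change at this position, with the rest of compound 2 held constant, can move the cell reading beyond the scatter, which the two separate numbers for compound 1 and compound 2 could not show. Compound 4 is a limit and not a number, so the step has a lower bound but no full size because the reading stops at a limit: the limit of < 2820 nM in this assay, at which 1 of the 4 values shown sits.

The compounds shown leave open whether the shift belongs to methanesulfonamido as a whole or would also follow from an amine or a carboxylic acid on the same aromatic carbon, and a single step on one core cannot separate these cases or say why the reading moved. Compound 3, with an amine on the furan in place of the nitro group, has no result in this assay, so the part played by that nitro group in the cell reading also stays unread.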